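The compounds below may be only part of what the source reports. "The series", "measured", "known", "first", "only" and "open" are said of these compounds alone.

Working notes on the chalcone-type series sharing the benzoxaborole core of compound 1 `O=C(/C=C/c1ccc2c(c1)B(O)OC2)c1ccccc1`. In a functional assay on SK-OV-3 cells (Homo sapiens) for cytotoxicity, read by MTT assay, with a stated time of 48 h (on this read-out higher numbers stand for weaker inhibition and lower numbers for stronger inhibition), compound 1 gives 3400 nM, which is the second highest of the three numbers recorded so far. Its nearest neighbour is compound 3 `COc1ccccc1C(=O)/C=C/c1ccc2c(c1)B(O)OC2`, which in this assay gives 2600 nM; the change a 1.3-fold lower number from compound 1 to compound 3 (0.12 log units; within the scatter). The furthest is compound 2 `O=C(/C=C/c1ccc2c(c1)B(O)OC2)c1ccco1`, which gives 20700 nM; here a 6.1-fold higher number from compound 1 to compound 2 (0.78 log units; beyond the scatter).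

Compound 4 `O=C(O)c1ccc(C(=O)/C=C/c2ccc3c(c2)B(O)OC3)cc1` is not yet measured. Relative to compound 1 the difference is carboxy in place of hydrogen on an aromatic carbon.

Among the measured compounds shown here, of the measured steps, only the one from compound 1 to compound 3 bears directly, since it also places a group in place of hydrogen on an aromatic carbon of the same ring, and that step stayed within the scatter. The step to compound 2 changes the ring itself and is not comparable. For compound 4 the expected step is therefore small, a 1.2-fold higher number from compound 1 to compound 4 (0.07 log units; within the scatter), with no clear direction. The estimate for compound 4 in this assay is 4000 nM, with a range from 1500 nM to 12000 nM.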

Compound 4, half-maximal inhibitory concentration: > 100000 nM
Compound 4 gave a limit, no number (the forecaster's own chance of this, stated with the estimate: 3%); middle value at least 25-fold (1.39 log units) from the limit.
By their numbers in this assay, from the lowest: compounds 3 and 1 (each within the scatter of the next); then compound 2. At a limit, above all of these: compound 4.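

Carboxy in place of hydrogen, para to a large group, gives an at least 29-fold higher number from compound 1 to compound 4 (1.46 log units; beyond the scatter). Substitution on this aromatic ring is therefore not always silent, which the only earlier step of this kind, a 1.3-fold lower number from compound 1 to compound 3 (0.12 log units; within the scatter), could not show. The reading for compound 4 is a limit and not a number: the limit of > 100000 nM in this assay, at which 1 of the 4 values shown sits.

Methoxy and carboxy differ in both group and place, so the two steps do not separate the effect of the group from that of its place on the ring. On these data alone, how a methyl ester or an amine at the place of the carboxy group would read in this assay stays open, and with it whether the large step belongs to carboxy alone.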